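Swapping the cyclopentyl for a benzyl-triazole

This account rests on a few compounds, and the source may have more. Where it says the series, first, only, none or still open, it means among the compounds named here.

Compound 1 `CNc1ncc2c(-c3ccc(N4CCNCC4)nc3)nn(CC3CCCC3)c2n1` gives 640 nM in an assay for inhibition of tyrosine-protein kinase Mer (Homo sapiens), read by 33P incorporation, in the presence of a further agent that is not named here; on this read-out higher numbers stand for weaker inhibition and lower numbers for stronger inhibition.
Compound 2 `CNc1ncc2c(-c3ccc(N4CCNCC4)nc3)nn(CC3OCCO3)c2n1` gives 6200 nM in this assay.
Compound 3 `CNc1ncc2c(-c3ccc(OC)cc3)nn(CC3OCCO3)c2n1` gives 8700 nM in this assay.

Among these three, compound 1 has the lowest number, so it is the strongest inhibitor in the set. Its nearest neighbour is compound 2, which differs from it in one place: a 9.7-fold higher number from compound 1 to compound 2 (0.99 log units; beyond the scatter). Among the measured compounds shown here, compound 3 differs from compound 1 in two places and stands further away still, its value being higher than that of compound 2, though no single-change step connects it to compound 1.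

Compound 4 `CNc1ncc2c(-c3ccc(N4CCNCC4)nc3)nn(Cc3cn(Cc4ccccc4)nn3)c2n1` has not yet been measured. It differs from compound 1 by 1-benzyl-1H-1,2,3-triazol-4-yl in place of cyclopentyl on a saturated chain carbon bound to an aromatic nitrogen. For the measured compounds named here, the only measured step at this same place is the one from compound 1 to compound 2, where exchanging the cyclopentyl for a different five-membered ring gave a clearly higher number. The group entering in compound 4 is larger than either and carries an aromatic triazole and a benzyl ring, for which no measured comparison exists.

On that basis the number for compound 4 is expected to rise, by a step of about a 2.3-fold higher number from compound 1 to compound 4 (0.37 log units; beyond the scatter) from compound 1, giving an estimated 1500 nM with a likely range from 300 nM to 8000 nM.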

Compound 4, half-maximal inhibitory concentration: 2300 nM
Compound 4: the middle estimate sits 1.5-fold (0.19 log units) below what was measured; low and high end bracket the measured number.
By their numbers in this assay, from the lowest: compound 1; then compound 4; then compounds 2 and 3 (each within the scatter of the next).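

In this assay, this position on the saturated chain carbon bound to an aromatic nitrogen accepts a much larger group than cyclopentyl at a modest cost: 1-benzyl-1H-1,2,3-triazol-4-yl, with 12 heavy atoms and two aromatic rings, gives (a 3.6-fold higher number from compound 1 to compound 4 (0.56 log units; beyond the scatter)). The same group compares favourably with 1,3-dioxolan-2-yl (a 2.7-fold lower number from compound 2 to compound 4 (0.43 log units; beyond the scatter)), so the three groups tried here do not rank by size alone, since the largest of them does not give the highest number. Cyclopentyl, a ring of carbon only with no hydrogen-bond acceptors, still gives the lowest number of the three, while both groups that carry hetero atoms give higher numbers, although the step to the benzyl-triazole is the smaller one.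

These compounds do not separate the contribution of the triazole from that of the benzyl ring, which a 1-methyl-1H-1,2,3-triazol-4-yl group or a plain phenyl at the same place would begin to do. No measurement shown here explains why the three groups differ in this way.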